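Cyclobutenedione series: removing a methyl from the branched amine

This account rests on a few compounds, and the source may have more. Where it says the series, first, only, none or still open, it means among the compounds named here.

Measured so far:
Compound 1, `CCC(C)(C)/N=c1\c(O)c(O)\c1=N/Cc1ccc(C#N)c(Cl)c1`, in a functional assay for inhibition, with Rattus norvegicus as the target (a higher number here means a weaker inhibitor, a lower number a stronger inhibitor), compound 1 gives 260 nM.
Compound 2, `CCC(C)(C)/N=c1\c(O)c(O)\c1=N/Cc1ccc(F)cc1Cl`, in this assay compound 2 gives 1500 nM.
Compound 3, `CC(C)(C)/N=c1\c(O)c(O)\c1=N/Cc1ccc(C#N)c(Cl)c1`, in this assay compound 3 gives 1100 nM.

Compound 1 and compound 3 share the same benzyl part and differ only at the branched amine end: hydrogen in place of methyl on a saturated chain carbon, two bonds along the chain from a double-bonded nitrogen. That change costs potency, a 4.2-fold higher number from compound 1 to compound 3 (0.63 log units; beyond the scatter). Compound 2 and compound 3 stand within the scatter of each other, so no order between them is claimed. Compound 1 and compound 2 differ in more than one place at the benzyl part; the difference between these two cores is not broken down here, and only their two values can be compared, which set compound 1 well apart from compound 2.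

Compound 4, `CC(C)(C)/N=c1\c(O)c(O)\c1=N/Cc1ccc(F)cc1Cl`, is not yet measured. It differs from compound 2 in the same way that compound 3 differs from compound 1: hydrogen in place of methyl on a saturated chain carbon, two bonds along the chain from a double-bonded nitrogen. Both place lines read identically, so this is the same change carried onto the other benzyl part. On a single matched pair the transfer of the step is uncertain, and compound 2 already stands at the high end of the three numbers.

For compound 4 in this assay a step of about a 3.3-fold higher number from compound 2 to compound 4 (0.52 log units; beyond the scatter) is expected, resting on the step seen from compound 1 to compound 3, a 4.2-fold higher number from compound 1 to compound 3 (0.63 log units; beyond the scatter). Compound 4 is therefore estimated at 5000 nM, with a plausible range from 2000 nM to 15000 nM.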

Compound 4, half-maximal inhibitory concentration: 1400 nM
Beside the measured number, compound 4's estimate is 3.6-fold (0.55 log units) above it, outside the stated range (below it).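

In this assay, cutting 1,1-dimethylpropyl back to tert-butyl on the core of compound 2 gives a 1.1-fold lower number from compound 2 to compound 4 (0.03 log units; within the scatter), so on this core the loss of the methyl leaves no readable change in the number. Set beside the core of compound 1, the same change does not carry over at a common size: the same change on two cores in this assay, a 4.2-fold higher number (0.63 log units; beyond the scatter) from compound 1 to compound 3 and a 1.1-fold lower number (0.03 log units; within the scatter) from compound 2 to compound 4, 4.5-fold (0.66 log units) apart, beyond the scatter of two such steps

Within these four compounds, the step read on one benzyl part is therefore no safe guide to the step on the other, but two matched pairs give no rule for further cores, and they do not show which of the differences between the two benzyl parts goes with the gap, or why it arises.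

Still open, from the compounds shown here alone, is how other groups at the amine end, such as isopropyl or a longer chain, would behave on both cores, and whether the gap between the two steps would persist there. Also open, going by these compounds, is whether a benzyl part carrying the nitrile without the chlorine, or one carrying a methoxy group, would follow the step seen on the core of compound 1 or the one seen on the core of compound 2.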